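A few compounds are considered here, and "the series" means these few. Any claim that something is new, unique, unknown or untested is made for them only; others in the source may bear on it.

The measured compounds: Compound 1 `c1csc(C2=NNC(c3ccc(N4CCCCC4)cc3)C2)c1` gives 3200 nM in an ADME assay on Vero cells (Chlorocebus sabaeus) for cytotoxicity, with a stated time of 5 days; a higher number here means a weaker inhibitor, a lower number a stronger inhibitor. Compound 2 `Clc1ccc(C2=NNC(c3ccc(N4CCCCC4)cc3)C2)s1` reaches only a limit of this assay, > 100000 nM. Compound 3 `Clc1cc(C2=NNC(c3ccc(N4CCCCC4)cc3)C2)c(Cl)s1` gives 53900 nM in this assay.

Compound 3 stands at the highest of the two numbers shown in this assay; its nearest neighbour is compound 1, with a 17-fold higher number from compound 1 to compound 3 (1.23 log units; beyond the scatter). The remaining value is a limit, (the limit of > 100000 nM in this assay, at which 1 of the 3 values shown sits), so compound 2 cannot be ranked against compound 3 beyond noting an at least 1.8-fold lower number from compound 2 to compound 3 (0.26 log units; that floor lies within the scatter).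

Compound 4 `Brc1ccc(C2=NNC(c3ccc(N4CCCCC4)cc3)C2)s1` differs from compound 3 in one place: 5-bromothiophen-2-yl in place of 2,5-dichlorothiophen-3-yl on a carbon with a double bond to nitrogen. For the measured compounds named here, two measured steps bear on this. The first is an at least 31-fold higher number from compound 1 to compound 2 (1.49 log units; beyond the scatter), which moved the number from a measurable value up to the limit. The second is an at least 1.8-fold lower number from compound 2 to compound 3 (0.26 log units; that floor lies within the scatter), which stays within the scatter. Going by the values given here, compound 4 carries a halogen at the same ring position as compound 2, so the closest precedent is compound 2, whose value sits at the limit. A step no larger than the scatter, or a modest rise, is therefore expected in this assay, written as a 1.9-fold higher number from compound 3 to compound 4 (0.27 log units; within the scatter). Compound 4 is estimated at 100000 nM, with a range from 30000 nM to 300000 nM, and a real chance that this assay again reports only a limit.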

Compound 4, half-maximal inhibitory concentration: 25800 nM
Estimate against measurement, compound 4: 3.9-fold (0.59 log units) above, and the stated range ends above it.
By their numbers in this assay, from the lowest: compound 1; then compound 4; then compound 3. At a limit, above all of these: compound 2.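

With 5-bromothiophen-2-yl on the carbon with a double bond to nitrogen, the identity of the halogen proves to matter in this assay: for bromo in place of chloro on an aromatic carbon, the change gives an at least 3.8-fold lower number from compound 2 to compound 4 (0.58 log units; beyond the scatter). Bromo still raises the number relative to hydrogen on that carbon, and an 8.1-fold higher number from compound 1 to compound 4 (0.91 log units; beyond the scatter) puts a measured size on such a halogen step for the first time, which the chloro step could only bound, as compound 2 stands at a limit: the limit of > 100000 nM in this assay, at which 1 of the 4 values shown sits. The swap of the whole ring group gives a 2.1-fold lower number from compound 3 to compound 4 (0.32 log units; beyond the scatter), so the single bromo of 5-bromothiophen-2-yl leaves the number below that of the two chlorines of 2,5-dichlorothiophen-3-yl.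

On these data alone, only hydrogen, chloro and bromo appear on these rings, so it remains open whether a methyl, a methoxy or a nitrile on that aromatic carbon would also raise the number from that of compound 1. As far as these compounds go, the true distance between chloro and bromo also stays open, since only its floor can be read.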